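A few compounds are considered here, and "the series" means these few. Any claim that something is new, unique, unknown or untested is made for them only; others in the source may bear on it.

Working notes on the series, in a physicochemical assay for solubility, with a stated time of 18 h, at pH 7.4; on this read-out lower numbers stand for lower solubility and higher numbers for higher solubility.

Compound 1 `COc1ccc(F)cc1CNCCCNc1ccnc2cc(Oc3ccc(F)cc3)ccc12` gives 14500 nM in this assay. Compound 2 `COc1ccc(F)cc1CNCCCNc1ccnc2cc(Oc3cccc(N(C)C)c3)ccc12` gives 14500 nM; the step of no change at the digits printed from compound 1 to compound 2 (within the scatter) shows no movement. Compound 3 `COc1ccc(F)cc1CNCCCNc1ccnc2cc(-c3ccc(C(F)(F)F)cc3)ccc12` gives 32000 nM and stands highest of the three, separated from compound 1 by a 2.2-fold higher number from compound 1 to compound 3 (0.34 log units; beyond the scatter) and from compound 2 by a 2.2-fold higher number from compound 2 to compound 3 (0.34 log units; beyond the scatter), both modest and beyond the scatter.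

Compound 4 `COc1ccc(F)cc1CNCCCNc1ccnc2cc(-c3cccc4ccccc34)ccc12` is not yet measured. It differs from compound 3 by naphthalen-1-yl in place of 4-(trifluoromethyl)phenyl on an aromatic carbon. Both measured steps that move the number swap an aryl ether for a directly attached aryl ring; the aryl-for-aryl swap between compound 1 and compound 2 moves nothing. Within the data shown here, no measured step exchanges one directly attached aryl ring for another, so nothing bears on this change directly, and the only comparable exchange is the silent one from compound 1 to compound 2.

The step from compound 3 to compound 4 is therefore expected to be a 1.3-fold lower number from compound 3 to compound 4 (0.11 log units; within the scatter), within the scatter. Compound 4 is estimated at 25000 nM, in the range 10000 nM to 60000 nM.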

Compound 4, solubility: 32000 nM
Beside the measured number, compound 4's estimate is 1.3-fold (0.11 log units) below it, within the range that was stated.
By their numbers in this assay, from the lowest: compounds 1 and 2 (each within the scatter of the next); then compounds 3 and 4 (each within the scatter of the next).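

In this assay this position now has a measured exchange of one directly attached aryl ring for another: naphthalen-1-yl in place of 4-(trifluoromethyl)phenyl gives no change at the digits printed from compound 3 to compound 4 (within the scatter) even though a single carbon-only ring with three fluorines gives way to two fused carbon-only rings. The separation from the aryl ethers also recurs with a second directly attached ring, as a 2.2-fold higher number from compound 2 to compound 4 (0.34 log units; beyond the scatter) and as a 2.2-fold higher number from compound 1 to compound 4 (0.34 log units; beyond the scatter), and none of the four compounds goes against this split. No measurement available here gives a reason for either reading.

From the compounds shown here alone, whether a directly attached ring carrying an amine or a carboxylic acid would read the same at this position stays open. Going by these compounds, all four compounds also share one side chain, so the effect of a longer chain there, and whether the split between aryl ethers and directly attached rings survives it, also stays open.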